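Compound 2 to compound 3: a rearranged amide side chain

The source may hold more compounds than are shown below. What is called first, only, known or untested is meant among the compounds shown, and "the series" means these compounds.

Measured in an ADME assay on CEM-SS cells (Homo sapiens) for cytotoxicity, read by XTT assay, with a stated time of 6 days; a lower number here means that less compound is tolerated, a higher number that more compound is tolerated:
- compound 1 `CCCC(=O)OCSc1ccccc1C(=O)NCCCCC(N)=O` gives 51.7 uM here
- compound 2 `CCCC(=O)OCSc1ccccc1C(=O)N(C)CC(=O)N(C)C` gives 57.3 uM here

Compound 2 stands level with compound 1, as the two values lie within the scatter of each other. Compound 3 `CCCC(=O)OCSc1ccccc1C(=O)NCC(=O)NC(C)C` carries ((isopropylcarbamoyl)methyl)amino in place of ((dimethylcarbamoyl)methyl)(methyl)amino on a carbonyl carbon. Going by the values given here, the only measured step at that place, a 1.1-fold higher number from compound 1 to compound 2 (0.04 log units; within the scatter), stayed within the scatter, so no step beyond the scatter, in either direction, is expected in this assay here. The estimated change is a 1.0-fold lower number from compound 2 to compound 3 (0.02 log units; within the scatter). For compound 3 the expected value is 55 uM, with an estimated range of 28 uM to 105 uM.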

Compound 3, half-maximal toxic concentration: 92 uM
The estimate for compound 3 lay 1.7-fold (0.22 log units) below the measured number; the measured number falls inside the stated range.
By their numbers in this assay, from the lowest: compounds 1, 2 and 3 (each within the scatter of the next).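

In this assay, the same atoms joined differently, with hydrogen-bond donors now present in the side chain, give a 1.6-fold higher number from compound 2 to compound 3 (0.21 log units; within the scatter). Isopropylcarbamoyl in place of 3-carbamoylpropyl on a saturated chain carbon bound to an amide-type nitrogen gives a 1.8-fold higher number from compound 1 to compound 3 (0.25 log units; within the scatter), so neither change moves the number beyond the scatter, and the three side chains stand level here. Nothing available accounts for this result. From the compounds shown here alone, whether a carboxylic acid or an amine at the end of this side chain would also leave the number level stays open.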